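The source may hold more compounds than are shown below. What is called first, only, known or untested is meant among the compounds shown, and "the series" means these compounds.

Compound 1 `Nc1nc(O)c2ncn(C/C=C/CO)c2n1`: 200000 nM
Compound 2 `Cc1cn(C=C=CCO)c(=O)nc1N`: 620000 nM

In a functional assay on L1210 cells (Mus musculus) for inhibition (a higher number here means a weaker inhibitor, a lower number a stronger inhibitor), compound 1 gives 200000 nM, the lower of the two numbers; compound 2 gives 620000 nM. Compound 3 `Nc1nc(O)c2ncn(CC#CCO)c2n1` has not yet been measured. It differs from compound 1 by a single change (3-hydroxyprop-1-yn-1-yl in place of 3-hydroxyprop-1-en-1-yl on a saturated chain carbon bound to an aromatic nitrogen). For the measured compounds named here, no pair of measured compounds shows this kind of change, so the size of the step can only be guessed. The step of no change at the digits printed from compound 1 to compound 3 (within the scatter) is expected to stay within the scatter, in either direction. Compound 3 is therefore expected to give about 200000 nM, within a range from 50000 nM to 800000 nM.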

Compound 3, half-maximal inhibitory concentration: 210000 nM
For compound 3 the middle estimate is 1.1-fold (0.02 log units) below the measured one; the range from low to high includes it.
By their numbers in this assay, from the lowest: compounds 1 and 3 (each within the scatter of the next); then compound 2.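

In this assay, for the compounds shown here, the change at this position reads as a 1.1-fold higher number from compound 1 to compound 3 (0.02 log units; within the scatter) and gives the first direct comparison, since no earlier pair differed in one place. On a saturated chain carbon bound to an aromatic nitrogen, 3-hydroxyprop-1-yn-1-yl and 3-hydroxyprop-1-en-1-yl therefore cannot be told apart in this assay. Nothing available explains this equivalence. Still open, on these data alone, is whether a fully saturated 4-hydroxybutyl chain would read the same on the shared core, and whether an amine or a carboxylic acid in place of the terminal hydroxyl would shift the number.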